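Chain length on the sulfur: from compound 3 to compound 4

The source may hold more compounds than are shown below. What is called first, only, known or untested is meant among the compounds shown, and "the series" means these compounds.

Compound 3 `CC1=CCC[C@H]2[C@](C)(CC3=CC(=O)C(SC(C)C)=CC3=O)[C@@H](C)CC[C@]12C` gives 47500 nM in a functional assay on K562 cells (Homo sapiens) for cytotoxicity, read by MTT assay (a lower number here means a stronger inhibitor, a higher number a weaker inhibitor), the highest of the two numbers in hand. Compound 1 `CC1=CCC[C@H]2[C@](C)(CC3=CC(=O)C(SC(C)(C)C)=CC3=O)[C@@H](C)CC[C@]12C` gives 25700 nM in this assay; a 1.8-fold higher number from compound 1 to compound 3 (0.27 log units; within the scatter), hydrogen in place of methyl on the saturated carbon bound to the sulfur, so the two sit together. Compound 2 `CCCCCCCCSC1=CC(=O)C(C[C@]2(C)[C@@H](C)CC[C@]3(C)C(C)=CCC[C@@H]23)=CC1=O` gives only a limit, > 100000 nM, in this assay (the limit of > 100000 nM in this assay, at which 1 of the 3 values shown sits). Lengthening the sulfur chain has so far cost potency: an at least 3.8-fold higher number from compound 1 to compound 2 (0.59 log units; beyond the scatter) with octyl in place of tert-butyl, and an at least 2.1-fold lower number from compound 2 to compound 3 (0.32 log units; beyond the scatter) with isopropyl in place of octyl.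

Compound 4 `CCCCSC1=CC(=O)C(C[C@]2(C)[C@@H](C)CC[C@]3(C)C(C)=CCC[C@@H]23)=CC1=O` differs from compound 3 by butyl in place of isopropyl on a sulfur. Butyl lies between isopropyl and octyl in length, so a step toward the weaker end is expected, though smaller than the steps involving octyl. The expected step is a 1.5-fold higher number from compound 3 to compound 4 (0.17 log units; within the scatter). Compound 4 is estimated at 70000 nM in this assay, within 30000 nM to 150000 nM, with a real chance that only a limit is returned.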

Compound 4, half-maximal inhibitory concentration: 12500 nM
Compound 4: middle estimate off by 5.6-fold (0.75 log units), on the high side; the whole stated range lies above it.
By their numbers in this assay, from the lowest: compound 4; then compounds 1 and 3 (each within the scatter of the next). At a limit, above all of these: compound 2.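

Chain length on the sulfur does not act in one direction: butyl, the straight chain, gives the lowest number of the four compounds, with a 3.8-fold lower number from compound 3 to compound 4 (0.58 log units; beyond the scatter) and a 2.1-fold lower number from compound 1 to compound 4 (0.31 log units; beyond the scatter), so it stands clear of both branched groups, isopropyl and tert-butyl. The longer straight chain does not keep this gain, with an at least 8.0-fold lower number from compound 2 to compound 4 (0.90 log units; beyond the scatter), so the earlier reading that a longer sulfur chain costs potency holds for octyl but goes against butyl. The octyl figure is a limit and not a number, so the size of that loss stays unfixed: the limit of > 100000 nM in this assay, at which 1 of the 4 values shown sits.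

With only butyl and octyl as straight chains, the compounds shown leave open where the gain peaks and fades, which a propyl or hexyl chain would help to place. From the compounds shown here alone, whether the sulfur itself is needed also stays open, and a butylamino group in place of butylsulfanyl would test that.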